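The source may report more compounds than this note shows. Statements on the series, on what has been measured and on what is new or still open speak of the compounds shown alone.

Of the compounds shown here, two have been measured in a functional assay on HeLa cells (Homo sapiens) for cytotoxicity, read by MTT assay (a lower number here means a stronger inhibitor, a higher number a weaker inhibitor), so far. Compound 1 `CCOC(=O)C12C(=O)OCC=C1COC2c1ccccc1F` gives 22100 nM in this assay. Compound 2 `CCOC(=O)C12C(=O)OCC=C1COC2c1cc(OC)cc(OC)c1`, which carries a different aromatic group on the same core, gives 16000 nM in this assay. The two numbers lie within the usual scatter of one another, so compound 1 stands level with compound 2, and both are weak inhibitors of cell growth on this scale.

Compound 3 `CCOC(=O)C12C(=O)OCC=C1COC2c1ccccn1` is the next compound to be tested. It differs from compound 1 in one place: pyridin-2-yl in place of 2-fluorophenyl on a saturated ring carbon, a pyridin-2-yl in place of 2-fluorophenyl on a saturated ring carbon. Among the compounds with values here, no measured pair shows the effect of such a swap, and the two numbers in hand give no direction for it. The step from compound 1 to compound 3 is therefore expected to stay within the scatter, at a 1.0-fold lower number from compound 1 to compound 3 (0.00 log units; within the scatter). Compound 3 is estimated at 22000 nM, in a range from 8000 nM to 60000 nM.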

Compound 3, half-maximal inhibitory concentration: 20700 nM
The estimate for compound 3 lay 1.1-fold (0.03 log units) above the measured number, and the stated range covers the measured number.
By their numbers in this assay, from the lowest: compounds 2, 3 and 1 (each within the scatter of the next).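

Within the data shown here, this is the first measured swap at this position: in this assay, pyridin-2-yl in place of 2-fluorophenyl gives a 1.1-fold lower number from compound 1 to compound 3 (0.03 log units; within the scatter) and so the two compounds stand level. On the core of compound 1, an aromatic ring that has a nitrogen and a hydrogen-bond acceptor and lacks the fluorine therefore makes no readable difference at this saturated ring carbon. No measurement at hand offers an explanation for this result.

All the compounds shown carry a six-membered aromatic ring at this carbon, so they leave open whether an amine, a carboxylic acid or a longer alkyl chain there would shift the number. On these data alone, they also keep the ethoxycarbonyl group throughout, so what an amide in its place would do remains open.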